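The source may report more compounds than this note shows. Statements on the series, on what has been measured and on what is new or still open speak of the compounds shown alone.

Measured compounds:
- compound 1 `N=C(NCCCc1c[nH]cn1)NCCCC(c1ccc(F)cc1)c1ccccn1`: in a functional assay on ileum for antagonist activity at histamine H1 receptor (Cavia porcellus) (on this read-out higher numbers stand for weaker binding and lower numbers for tighter binding), compound 1 gives 46.8 nM
- compound 2 `N=C(NCCCc1c[nH]cn1)NCCC(c1ccc(F)cc1)c1ccccn1`: in this assay compound 2 gives 22.4 nM

Both compounds share the same core and differ in the length of the chain between the guanidine and the branching carbon. Going by the values given here, on the two numbers so far, compound 2 stands at the lower of the two in this assay, and compound 1 at the higher, the two values sitting apart by a margin that is beyond the scatter; no further comparison between them is drawn here.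

Compound 3 `N=C(NCCCc1c[nH]cn1)NCCC(c1ccc(Br)cc1)c1ccccn1` is not yet measured in this assay. It differs from compound 2 in one place: bromo in place of fluoro on an aromatic carbon, para to a large group. Among the compounds with values here, no pair among the measured compounds shows this kind of exchange, so there is no step on file from which to read its size. Compound 3 is expected to land close to compound 2, with the step of a 1.2-fold lower number from compound 2 to compound 3 (0.09 log units; within the scatter) small and likely within the scatter. The estimate for compound 3 is 18 nM, within a range from 6 nM to 55 nM.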

Compound 3, dissociation constant: 120 nM
For compound 3 the middle estimate is 6.7-fold (0.82 log units) below the measured one; the whole stated range lies below it.
By their numbers in this assay, from the lowest: compound 2; then compound 1; then compound 3.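

In this assay, the exchange of 4-fluorophenyl for 4-bromophenyl gives a 5.4-fold higher number from compound 2 to compound 3 (0.73 log units; beyond the scatter), a modest step but one beyond the scatter. Going by these compounds alone, this place on the aromatic ring is therefore not indifferent to which of these two halogens it carries, something the earlier compounds could not show, as both carry fluoro there and differ only in chain length. The reading rests on a single pair with the chain of compound 2, and no measurement on hand speaks to what lies behind the size or direction of the step.

From the compounds shown here alone, two halogens define no trend, so it remains open whether chloro, methoxy or plain hydrogen at the same place would fall with fluoro, with bromo or elsewhere. Also open, going by these compounds, is whether the same exchange on the longer chain of compound 1 would give a step of like size and direction, or whether the effect of this change depends on chain length.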